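A few compounds are considered here, and "the series" means these few. Any claim that something is new, unique, unknown or untested is made for them only; others in the source may bear on it.

Compounds measured in a functional assay (Cavia porcellus) for antagonist activity at Serotonin 3 (5-HT3) receptor (Homo sapiens); on this read-out lower numbers stand for stronger inhibition and higher numbers for weaker inhibition:
compound 1 `O=C1N(c2cccc(Cl)c2)CCN1C1CN2CCC1CC2` gives 30.9 nM
compound 2 `CSc1cccc(N2CCN(C3CN4CCC3CC4)C2=O)c1` gives 214 nM
compound 3 `O=C1N(c2ccccc2)CCN1C1CN2CCC1CC2` gives 2100 nM

Compound 3, the unsubstituted phenyl, stands highest of the three numbers in this assay; its nearest neighbour is compound 2, and compound 1 is furthest away, both steps beyond the scatter.

Compound 4 `O=C1N(c2cccc([N+](=O)[O-])c2)CCN1C1CN2CCC1CC2` is the next member. Compared with compound 3 the change is nitro in place of hydrogen on an aromatic carbon.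

For the measured compounds named here, two measured steps bear on this change, as both touch the same aromatic carbon of compound 3. The step of a 68-fold higher number from compound 1 to compound 3 (1.83 log units; beyond the scatter) shows how much the number rises when chloro is taken away; the step of a 9.8-fold higher number from compound 2 to compound 3 (0.99 log units; beyond the scatter) shows the rise when methylsulfanyl is taken away. Read in the opposite direction, putting any of the two groups onto the bare ring of compound 3 lowered the number, modestly to largely. With only two substituents known at this place, the size for nitro is open, but a drop beyond the scatter is expected, somewhere between the two observed sizes.

For compound 4 the step is therefore expected to be a 14-fold lower number from compound 3 to compound 4 (1.15 log units; beyond the scatter), giving an estimate of 150 nM with a range from 40 nM to 600 nM.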

Compound 4, antagonist equilibrium constant: 75.2 nM
The estimate for compound 4 lay 2.0-fold (0.30 log units) above the measured number, and the stated range covers the measured number.
By their numbers in this assay, from the lowest: compound 1; then compound 4; then compound 2; then compound 3.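

In this assay, nitro joins chloro and methylsulfanyl as a third group that lowers the number on this aromatic carbon, with a 28-fold lower number from compound 3 to compound 4 (1.45 log units; beyond the scatter), so among the compounds shown, the bare phenyl of compound 3 stands highest against all three substituents. The substituents are also separated from one another, not merely from hydrogen: a 2.8-fold lower number from compound 2 to compound 4 (0.45 log units; beyond the scatter) and a 2.4-fold higher number from compound 1 to compound 4 (0.39 log units; beyond the scatter), both beyond the scatter, which gives the order chloro, nitro, methylsulfanyl, hydrogen from the lowest number to the highest. The size of the drop at this place therefore depends on the group that enters, but no measurement available here accounts for that order.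

Open, going by these compounds, is whether an amine, a carboxylic acid or a trifluoromethyl on this aromatic carbon would keep the number low, or take it under that of compound 1 at 30.9 nM. Also open, on these data alone, is whether the order of these four groups would hold on another carbon of the same aromatic ring, or with a change elsewhere in the shared core.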